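This account rests on a few compounds, and the source may have more. Where it says the series, first, only, none or still open, it means among the compounds named here.

Compound 1 `CCCc1n[nH]c2c(=O)n(NC(=O)c3ccccc3)c(-c3cccc([N+](=O)[O-])c3)nc12` gives 33.2% in a functional assay on A549 cells (Homo sapiens) for cytotoxicity, read by sulforhodamine B assay, with a stated time of 2 days, tested at 100 uM; on this read-out higher numbers stand for more inhibition at the one concentration tested (going by the name of the read-out) and lower numbers for less inhibition.
Compound 2 `CCCc1n[nH]c2c(=O)n(NC(=O)c3ccccc3)c(-c3cccc(OC)c3)nc12` gives 20.7% in this assay.
Compound 3 `COc1cccc(-c2nc3c(-c4cccc(Cl)c4)n[nH]c3c(=O)n2NC(=O)c2ccccc2)c1` is recorded as "not determined" (no result reported) in this assay, so no number is available for it.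

Compound 1 stands highest of the two numbers recorded; its nearest neighbour is compound 2, separated by a number 12.5 percentage points lower from compound 1 to compound 2 (beyond the scatter), a gap beyond the usual scatter. Compound 4 `O=C(Nn1c(-c2cccc([N+](=O)[O-])c2)nc2c(-c3ccc(Cl)cc3)n[nH]c2c1=O)c1ccccc1` differs from compound 1 by 4-chlorophenyl in place of propyl on an aromatic carbon. Going by the values given here, no measured step bears directly on this change: the only step on record exchanges methoxy for nitro, a different alteration, and compound 3, the sole compound that carries an aryl group where compound 4 does, has no number. The expectation therefore rests on compound 1 alone and carries a wide range. Compound 4 is estimated at 33% (from 13% to 53%), and the step of a number 0.2 percentage points lower from compound 1 to compound 4 (within the scatter) is expected to stay within the scatter.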

Compound 4, a percentage reported as inhibition, at one concentration (the size of the read-out at that concentration, not a potency): 88.6%
For compound 4 the middle estimate is 55.6 percentage points below the measured one, outside the stated range (above it).
By their numbers in this assay, from the lowest: compound 2; then compound 1; then compound 4.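

Putting 4-chlorophenyl in place of propyl on this aromatic carbon gives a number 55.4 percentage points higher from compound 1 to compound 4 (beyond the scatter) in this assay. The earlier numbers came only from a change on the other aryl ring, so they gave no sign that this position could shift the read-out so strongly. Nothing measured here explains the rise.

Whether the added ring or its chlorine accounts for the step stays open. So does what a plain phenyl, a longer chain or an amine would give on this carbon.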